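Notes on the Carbonyl Substituent of Compound 2

The compounds below may be only part of what the source reports. "The series", "measured", "known", "first", "only" and "open" are said of these compounds alone.

Compound 1 `C#CC[C@@H]1C[C@H](n2cccc2)C(=O)O1`: >= 100000 nM, a limit of the assay
Compound 2 `C#CC[C@@H]1C[C@H](n2cccc2C(=O)CC)C(=O)O1`: 40600 nM

In an ADME assay on N2a cells (Mus musculus) for cytotoxicity, read by MTT assay (on this read-out lower numbers stand for stronger inhibition and higher numbers for weaker inhibition), compound 1 gives >= 100000 nM, which is a limit of the assay, not a number. Among the measured compounds shown here, compound 2 gives 40600 nM in this assay, the only numerical value here. For the measured compounds named here, the one measured step is an at least 2.4-fold lower number from compound 1 to compound 2 (0.39 log units; beyond the scatter). Compound 3 `C#CC[C@@H]1C[C@H](n2cccc2C(=O)C(F)(F)F)C(=O)O1` differs from compound 2 by trifluoromethyl in place of ethyl on a carbonyl carbon. Going by the values given here, no measured step covers this change, since the step of an at least 2.4-fold lower number from compound 1 to compound 2 (0.39 log units; beyond the scatter) concerns presence of the acyl group rather than what sits on its carbonyl carbon, so no direction beyond the scatter is expected. Compound 3 is estimated at 30000 nM, between 10000 nM and 100000 nM, an expected step of a 1.4-fold lower number from compound 2 to compound 3 (0.13 log units; within the scatter).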

Compound 3, half-maximal inhibitory concentration: > 100000 nM
Compound 3 gave a limit, no number; the forecaster's own chance of this, stated with the estimate: 15%; middle value at least 3.3-fold (0.52 log units) away from the limit.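

In this assay the group on the carbonyl carbon matters, not only the presence of the acyl group: trifluoromethyl in place of ethyl gives an at least 2.4-fold higher number from compound 2 to compound 3 (0.39 log units; beyond the scatter), so the number for compound 2 is not kept across this change. This step is only a bound, since compound 3 stands at a limit of the assay, not a number: the limit of > 100000 nM in this assay, at which 1 of the 3 values shown sits. The step linking compound 1 and compound 3 cannot be read.

Only ethyl and trifluoromethyl are shown on the carbonyl carbon. From the compounds shown here alone, a longer chain or an amine at that place remains open.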